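This account rests on a few compounds, and the source may have more. Where it says the series, first, only, none or still open, it means among the compounds named here.

In an assay on BaF3 cells with thrombopoietin receptor (Homo sapiens) as the target, read by a luciferase reporter (a lower number here means a smaller maximal response, a higher number a larger maximal response), compound 2 `Cc1[nH]n(-c2cc(Cl)c(S(=O)(=O)O)cc2Cl)c(=O)c1/N=N/c1c(O)cc(S(=O)(=O)O)c2ccccc12` gives < 5%, which is a limit of the assay and not a measured number, the point noted as the limit of < 5% in this assay, at which 1 of the 2 values shown sits. Compound 1 `Cc1ccc(-n2[nH]c(C)c(/N=N/c3c(O)cc(S(=O)(=O)O)c4ccccc34)c2=O)cc1C` in this assay gives 100%. Within the data shown here, the only measured step is a number at least 95 percentage points lower from compound 1 to compound 2 (beyond the scatter), a large change going from a ring bearing only carbon to a ring bearing chlorine and a sulfonic acid group on the aromatic nitrogen.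

Compound 3 `Cc1[nH]n(-c2ccc(O)cc2)c(=O)c1/N=N/c1c(O)cc(S(=O)(=O)O)c2ccccc12` has not yet been measured. It differs from compound 2 as follows: a group of 7 heavy atoms (6 carbon, 1 oxygen; one six-membered aromatic ring of carbon only) in place of a group of 12 heavy atoms (6 carbon, 3 oxygen, 1 sulfur, 2 chlorine; one six-membered aromatic ring of carbon only), on an aromatic nitrogen. The step from compound 1 to compound 2 bears on this change, as it removes the chlorine and sulfur-containing group that entered in that step and restores a smaller carbon ring, here with a hydroxyl. A large step upward is therefore expected for compound 3, back toward where compound 1 stands. Compound 3 is expected to give 60%, within a range from 10% to 100%. The expected step is a number at least 55 percentage points higher from compound 2 to compound 3 (beyond the scatter).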

Compound 3, largest response reached (reported as efficacy), in percent of the reference or control that the assay uses: < 5%
Compound 3: only a limit was reported (the forecaster's own chance of this, stated with the estimate: 25%); middle value at least 55 percentage points away from the limit.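

The 4-hydroxyphenyl group of compound 3 carries no chlorine and no sulfonic acid, yet in this assay the response comes out a number at least 95 percentage points lower from compound 1 to compound 3 (beyond the scatter). The loss of response at this aromatic nitrogen therefore does not require the chlorine atoms or the sulfonic acid of compound 2, since replacing 3,4-dimethylphenyl with 4-hydroxyphenyl is enough on its own. The reading for compound 3 is a limit of the assay and not a number, so the step between compound 2 and compound 3 cannot be read: the limit of < 5% in this assay, at which 2 of the 3 values shown sit.

From the compounds shown here alone, it remains open whether the response depends on the two methyl groups of 3,4-dimethylphenyl or is lost specifically with the hydroxyl. A 4-methylphenyl or 4-methoxyphenyl group on the same nitrogen would help separate these two readings.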